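From 2-fluorophenyl to 3-methoxyphenyl: a small expected step

The compounds below may be only part of what the source reports. "The series", "measured", "known", "first", "only" and "open" are said of these compounds alone.

Measured so far in a functional assay on HL-60 cells (Homo sapiens) for cytotoxicity, read by WST assay, with a stated time of 48 h; on this read-out lower numbers stand for an effect already at smaller amounts and higher numbers for an effect only at larger amounts of compound
Compound 1 `O=C1OC[C@H](Cc2ccccc2)[C@H]1Cc1ccc(Cl)c(Cl)c1` gives 19000 nM
Compound 2 `COc1ccccc1C[C@H]1COC(=O)[C@@H]1Cc1ccc(Cl)c(Cl)c1` gives 14000 nM
Compound 3 `O=C1OC[C@H](Cc2ccccc2F)[C@H]1Cc1ccc(Cl)c(Cl)c1` gives 28000 nM

The last of these stands level with the other two, as a 1.5-fold higher number from compound 1 to compound 3 (0.17 log units; within the scatter) and a 2.0-fold higher number from compound 2 to compound 3 (0.30 log units; within the scatter) show. Compound 4 `COc1cccc(C[C@H]2COC(=O)[C@@H]2Cc2ccc(Cl)c(Cl)c2)c1` has not yet been measured. It carries 3-methoxyphenyl in place of 2-fluorophenyl on a saturated chain carbon bound to a saturated ring carbon. Among the measured compounds shown here, two measured steps bear on this change. Methoxy in place of hydrogen on an aromatic carbon gave a 1.4-fold lower number from compound 1 to compound 2 (0.13 log units; within the scatter) while fluoro in place of methoxy on an aromatic carbon gave a 2.0-fold higher number from compound 2 to compound 3 (0.30 log units; within the scatter) and both stayed within the scatter. For the measured compounds named here, no measured compound yet carries 3-methoxyphenyl. No step beyond the scatter is therefore expected in this assay and the step estimated here is a 1.6-fold lower number from compound 3 to compound 4 (0.19 log units; within the scatter) with its direction uncertain. For compound 4 the estimated value is 18000 nM with an expected range from 10000 nM to 32000 nM in this account.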

Compound 4, half-maximal effective concentration: 34000 nM
Compound 4: the middle estimate sits 1.9-fold (0.28 log units) below what was measured; measured number above the stated range.
By their numbers in this assay, from the lowest: compounds 2, 1, 3 and 4 (each within the scatter of the next, the first and the last beyond it).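

In this assay the exchange of 2-fluorophenyl for 3-methoxyphenyl stays level, with a 1.2-fold higher number from compound 3 to compound 4 (0.08 log units; within the scatter) and, against the unsubstituted phenyl, a 1.8-fold higher number from compound 1 to compound 4 (0.25 log units; within the scatter) also inside the scatter. Among the compounds shown here, what the earlier compounds did not show is that the place of the methoxy on the phenyl ring can register here: 3-methoxyphenyl in place of 2-methoxyphenyl gives a 2.4-fold higher number from compound 2 to compound 4 (0.39 log units; beyond the scatter) and is the only step so far to pass the scatter, though only modestly. Nothing measured here bears on the reason for that step.

Going by these compounds, whether the same difference would appear with a hydroxy group or an amine in place of methoxy on this phenyl ring remains open. So does whether a longer chain between the phenyl ring and the shared core would shift the number at all.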